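The source may report more compounds than this note shows. Statements on the series, on what has been measured and on what is new or still open speak of the compounds shown alone.

Measured so far in an ADME assay on PC-3 cells (Homo sapiens) for cytotoxicity, read by WST assay, tested at 100 uM; a lower number here means less inhibition, a higher number more inhibition at the concentration tested (going by the name of the read-out):
- compound 1, `O=C(Nc1cccc(Oc2ccccn2)c1)C1CCCN(C(=O)c2cc(C(F)(F)F)cc(C(F)(F)F)c2)C1`: 0%
- compound 2, `CCc1cccc(NC(=O)C2CCCN(C(=O)c3cc(C(F)(F)F)cc(C(F)(F)F)c3)C2)c1`: 0%
- compound 3, `O=C(Nc1cccc(Oc2nccc(C(F)(F)F)c2Cl)c1)C1CCCN(C(=O)c2cc(C(F)(F)F)cc(C(F)(F)F)c2)C1`: 0%

Compound 3 stands level with compound 1 and compound 2 at the digits given: no change at the digits printed from compound 1 to compound 3 (within the scatter) and no change at the digits printed from compound 2 to compound 3 (within the scatter) both lie within the scatter, as does no change at the digits printed from compound 1 to compound 2 (within the scatter). Three different groups on the same aromatic carbon of the shared core have left the read-out unchanged.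

Compound 4, `Cc1nc(-c2cccc(NC(=O)C3CCCN(C(=O)c4cc(C(F)(F)F)cc(C(F)(F)F)c4)C3)c2)cs1`, is not yet measured. It differs from compound 3 in one place: 2-methyl-1,3-thiazol-4-yl in place of (3-chloro-4-(trifluoromethyl)pyridin-2-yl)oxy on an aromatic carbon. Going by the values given here, the steps that bear on this are the earlier exchanges at that aromatic carbon, no change at the digits printed from compound 1 to compound 2 (within the scatter), no change at the digits printed from compound 2 to compound 3 (within the scatter) and no change at the digits printed from compound 1 to compound 3 (within the scatter), none of which moved the read-out beyond the scatter. On that basis no change beyond the scatter is expected in this assay for the step of no change at the digits printed from compound 3 to compound 4 (within the scatter). Compound 4 is expected to give 0%, in the range -10% to 12%. Among the compounds with values here, no earlier step brings a five-membered aromatic ring with 2 hetero atoms onto that aromatic carbon, so the estimate rests only on the uniform behaviour of compound 1, compound 2 and compound 3.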

Compound 4, a percentage reported as inhibition, at one concentration (the size of the read-out at that concentration, not a potency): 1%
Compound 4: middle estimate off by 1 percentage points, on the low side, within the range that was stated.
By their numbers in this assay, from the lowest: compounds 1, 2, 3 and 4 (each within the scatter of the next).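

In this assay, 2-methyl-1,3-thiazol-4-yl brings the first five-membered aromatic ring with 2 hetero atoms onto this aromatic carbon, and the result stays within the scatter against the (3-chloro-4-(trifluoromethyl)pyridin-2-yl)oxy group (a number 1 percentage points higher from compound 3 to compound 4 (within the scatter)), the ethyl group (a number 1 percentage points higher from compound 2 to compound 4 (within the scatter)) and the (pyridin-2-yl)oxy group (a number 1 percentage points higher from compound 1 to compound 4 (within the scatter)). Across compounds 1 to 4, the read-out therefore does not separate oxygen-linked six-membered rings, an alkyl group or a directly attached thiazole at this carbon, and the exchange from 12 heavy atoms to 6 heavy atoms, with sulfur entering and chlorine and fluorine leaving, also stays within the scatter. No supporting evidence bears on why this position is so uniform.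

On these data alone, whether an amine or a carboxylic acid on this aromatic carbon would fit the same picture stays open. So does whether replacing a trifluoromethyl group elsewhere on the shared core with a longer chain would move the read-out.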